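This account rests on a few compounds, and the source may have more. Where it says the series, first, only, none or still open, it means among the compounds named here.

Compounds measured so far:
compound 1 `COc1cc(Cl)cc(-c2nn(-c3cccc(NC(=O)Nc4ccc(Cl)c(C(F)(F)F)c4)c3)cc2-c2ccncc2)c1` — 112%
compound 2 `COc1cc(Cl)cc(-c2nn(-c3cccc(NC(=O)Nc4cc(C(F)(F)F)cc(C(F)(F)F)c4)c3)cc2-c2ccncc2)c1` — 103%
compound 3 `COc1cc(Cl)cc(-c2nn(-c3cccc(NC(=O)Nc4ccc(Cl)c(Cl)c4)c3)cc2-c2ccncc2)c1` — 98%

All three were tested in a functional assay on IGROV-1 cells (Homo sapiens) for inhibition, read by sulforhodamine B assay, with a stated time of 48 h, tested at 0.01 uM; on this read-out lower numbers stand for a stronger effect and higher numbers for a weaker effect at the one concentration tested. Compound 3 gives the lowest of the three numbers, but only its gap to compound 1 is beyond the usual scatter: the step of a number 14 percentage points lower from compound 1 to compound 3 (beyond the scatter) was a modest one, brought about by chloro in place of trifluoromethyl on an aromatic carbon. Against compound 2, which gives 103%, compound 3 sits within the scatter, so no order between those two can be read.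

Compound 4 `COc1cc(Cl)cc(-c2nn(-c3cccc(NC(=O)Nc4cccc(C(F)(F)F)c4)c3)cc2-c2ccncc2)c1` has not yet been measured. It differs from compound 3 by 3-(trifluoromethyl)phenyl in place of 3,4-dichlorophenyl on an amide-type nitrogen. Among the measured compounds shown here, the only step that bears on it is the one from compound 1 to compound 3, where exchanging trifluoromethyl for chloro lowered the number modestly; compound 4 partly reverses that exchange and also drops one chlorine, so any effect is expected to be small. In this assay compound 4 is therefore expected to give 105%, within a range of 93% to 117%, a step of a number 7 percentage points higher from compound 3 to compound 4 (within the scatter) that is not expected to go beyond the scatter.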

Compound 4, a percentage reported as activity, at one concentration (the size of the read-out at that concentration, not a potency): 106%
Estimate against measurement, compound 4: 1 percentage points below; measured number inside the range.
By their numbers in this assay, from the lowest: compounds 3, 2, 4 and 1 (each within the scatter of the next, the first and the last beyond it).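

In this assay, the result adds three steps at the aryl group on the amide-type nitrogen, and none goes beyond the scatter: a number 8 percentage points higher from compound 3 to compound 4 (within the scatter) with 3-(trifluoromethyl)phenyl in place of 3,4-dichlorophenyl, a number 3 percentage points higher from compound 2 to compound 4 (within the scatter) with hydrogen in place of trifluoromethyl, and a number 6 percentage points lower from compound 1 to compound 4 (within the scatter) with hydrogen in place of chloro. Taking a single chloro or a single trifluoromethyl off this ring therefore gives no readable difference at the one concentration tested, so a number 14 percentage points lower from compound 1 to compound 3 (beyond the scatter) remains the only single-place step beyond the scatter. No measured finding accounts for these numbers.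

The compounds shown leave open whether an amine or a carboxylic acid on this phenyl ring would shift the number beyond the scatter. They also leave open whether the small gaps among these four compounds would hold at any other concentration.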